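This account rests on a few compounds, and the source may have more. Where it says the series, first, only, none or still open, it means among the compounds named here.

Compound 1 `COc1ccc(-n2nncc2CN2C(=O)C3(C(C#N)=C(N)Oc4c(N)cc5nc6ccccc6nc5c43)c3ccccc32)cc1`: in a functional assay on HepG2 cells (Homo sapiens) for antiproliferative activity, read by MTT assay, with a stated time of 48 h (on this read-out higher numbers stand for weaker inhibition and lower numbers for stronger inhibition), compound 1 gives only the limit > 50000 nM.
Compound 2 `CCc1cccc(C)c1-n1nncc1CN1C(=O)C2(C(C#N)=C(N)Oc3c(N)cc4nc5ccccc5nc4c32)c2ccccc21`: in this assay compound 2 gives only the limit > 50000 nM.

Going by the values given here, the single measured step, a step that the two limits leave unreadable from compound 1 to compound 2, cannot be read, since both values sit at the limit of > 50000 nM in this assay, at which 2 of the 2 values shown sit. Compound 2 therefore stands at that limit, with no number of its own. Compound 3 `N#CC1=C(N)Oc2c(N)cc3nc4ccccc4nc3c2C12C(=O)N(Cc1cnnn1-c1ccc([N+](=O)[O-])cc1[N+](=O)[O-])c1ccccc12` differs from compound 2 in one place: 2,4-dinitrophenyl in place of 2-ethyl-6-methylphenyl on an aromatic nitrogen. Among the compounds with values here, no measured step gives a readable size for this kind of change, so no step beyond the scatter is expected in this assay, in either direction. Compound 3 is estimated at 60000 nM, between 15000 nM and 200000 nM, an expected step that the limit leaves unreadable from compound 2 to compound 3.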

Compound 3, half-maximal inhibitory concentration: 18400 nM
Estimate against measurement, compound 3: 3.3-fold (0.51 log units) above, and the stated range covers the measured number.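

The aryl group on the aromatic nitrogen of the five-membered ring can change the read-out after all: 2,4-dinitrophenyl in place of 2-ethyl-6-methylphenyl gives an at least 2.7-fold lower number from compound 2 to compound 3 (0.43 log units; beyond the scatter) in this assay. The same group in place of 4-methoxyphenyl gives an at least 2.7-fold lower number from compound 1 to compound 3 (0.43 log units; beyond the scatter). Both sizes are only lower bounds, because compound 1 and compound 2 sit at a limit: the limit of > 50000 nM in this assay, at which 2 of the 3 values shown sit.

These compounds do not separate the effect of gaining the nitro groups from that of losing the earlier substituents. As far as these compounds go, whether one nitro group would suffice, or an amine or carboxylic acid on this phenyl ring would serve equally, remains open.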